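Swapping the chain-end group on a long-chain benzamide

This account rests on a few compounds, and the source may have more. Where it says the series, first, only, none or still open, it means among the compounds named here.

Of the compounds shown here, three sharing one core have been tested in an assay on HEK293 cells for displacement of a labelled ligand from 5-hydroxytryptamine receptor 4 (Homo sapiens), read by scintillation counting; a lower number here means a stronger inhibitor, a higher number a weaker inhibitor. Compound 1 `COc1cc(N)c(Cl)cc1C(=O)NC1CCN(CCN2C(=O)c3ccccc3C2=O)CC1` gives 7940 nM. Compound 2 `COc1cc(N)c(Cl)cc1C(=O)NC1CCN(CCCCCCCCN2C(=O)c3ccccc3C2=O)CC1`, which carries a much longer chain to the same end group, gives 39.8 nM. Compound 3 `COc1cc(N)c(Cl)cc1C(=O)NC1CCN(CCCCCN2CCCCC2)CC1`, which shares the core but differs in the chain and its end group, gives 10 nM. Compound 2 therefore stands between the other two, far away from compound 1 and closer to compound 3, though both gaps lie beyond the usual scatter.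

Compound 4 `COc1cc(N)c(Cl)cc1C(=O)NC1CCN(CCCCCCCCN2CCN(S(C)(=O)=O)CC2)CC1` keeps the core and the long chain of compound 2 and changes only the terminal group: a group of 10 heavy atoms (5 carbon, 2 nitrogen, 2 oxygen, 1 sulfur; one six-membered non-aromatic ring with 2 hetero atoms) in place of a group of 11 heavy atoms (8 carbon, 1 nitrogen, 2 oxygen; one five-membered non-aromatic ring with 1 hetero atom, one six-membered aromatic ring of carbon only), on a saturated chain carbon, eight bonds along the chain from an amine nitrogen in a ring. For the measured compounds named here, no pair of measured compounds differs in exactly this way, so the size of this step has to be guessed. Compound 3 ends its chain in a saturated ring rather than the two-ring group of compound 2. In this assay compound 3 gives 10 nM, which suggests the end group can be exchanged without loss. For compound 4 a small step downward, expected to be a 2.0-fold lower number from compound 2 to compound 4 (0.30 log units; within the scatter) and close to the scatter, seems most likely. Compound 4 is estimated at 20 nM, within a range from 5 nM to 80 nM.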

Compound 4, inhibition constant: 15.9 nM
Compound 4: the middle estimate sits 1.3-fold (0.10 log units) above what was measured; the measured number falls inside the stated range.
By their numbers in this assay, from the lowest: compounds 3 and 4 (each within the scatter of the next); then compound 2; then compound 1.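

On a saturated chain carbon, eight bonds along the chain from an amine nitrogen in a ring, replacing the end group of compound 2 with 4-(methylsulfonyl)piperazin-1-yl gives, in this assay, a 2.5-fold lower number from compound 2 to compound 4 (0.40 log units; beyond the scatter). For the compounds shown here, this is the first comparison in which the end group alone changes, whereas compound 3 differs from compound 2 in both its chain and its end group. At this chain length, the end group's six-membered aromatic ring of carbon only is therefore not needed to reach a low number, although the step is modest and this is a single pair. Nothing measured here explains why the number moves.

The compounds shown leave open whether the methylsulfonyl group itself contributes to the step or whether a piperazine ring bearing an acetyl group, or a plain piperazine with a free amine, would give a similar number. They also leave open whether 4-(methylsulfonyl)piperazin-1-yl would give a similar result on a shorter chain, where the end group may sit differently relative to the shared core.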